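The source may report more compounds than this note shows. Statements on the series, on what has been measured and on what is new or still open speak of the compounds shown alone.

Measured so far in a physicochemical assay for lipophilicity; a higher number here means a more lipophilic compound, a lower number a more polar compound:
compound 1 `CCCCCCOC(=O)c1ccc(S(N)(=O)=O)cc1`: 3.23
compound 2 `CCCCNC(=O)c1ccc(S(N)(=O)=O)cc1`: 1.05
compound 3 `CCOC(=O)c1cccc(S(N)(=O)=O)c1`: 1.11

Compound 3 gives 1.11, within the scatter of compound 2, which gives 1.05. Compound 1 gives 3.23, beyond the scatter from both.

Next in line is compound 4 `CCCCOC(=O)c1cccc(S(N)(=O)=O)c1`, not yet measured. The structural change from compound 3 to compound 4 is ethyl in place of hydrogen on a saturated chain carbon, two bonds along the chain from an oxygen next to a carbonyl group. The same difference reads ethoxy to butoxy.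

Within the data shown here, no measured pair isolates this change, so the size of the step in this assay has to be judged indirectly. Among the measured compounds shown here, the only guide is a hexyl ester that also differs from compound 3 elsewhere in the structure, namely compound 1 with its 3.23. A rise beyond the scatter is expected, covering part of the gap between those two values. The expected change is a number 0.99 log units higher from compound 3 to compound 4 (beyond the scatter). Compound 4 is estimated at 2.1, with an expected range of 1.75 to 2.45.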

Compound 4, partition coefficient: 2.24
Compound 4: middle estimate off by 0.14 log units, on the low side; low and high end bracket the measured number.
By their numbers in this assay, from the lowest: compounds 2 and 3 (each within the scatter of the next); then compound 4; then compound 1.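

Ethoxy to butoxy can now be read directly in this assay: the change gives a number 1.13 log units higher from compound 3 to compound 4 (beyond the scatter) and is marked as large. Among these compounds, this is the first measured pair that differs in one place, so the effect of adding ethyl on this saturated chain carbon no longer has to be inferred from compounds that also differ elsewhere. The position therefore accepts this extension with a clear shift in the read-out, but the data at hand offer no independent measurement that accounts for the size of the step.

One step cannot show whether each further addition to the chain would bring a similar shift, for example in going on to an octyl ester on this core. As far as these compounds go, it also remains open how the number would move with an amine or a hydroxyl group on the butoxy chain.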